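The source may report more compounds than this note shows. Statements on the series, on what has been measured and on what is new or still open speak of the compounds shown alone.

Compound 1, `Fc1ccc(-c2cn(C3CN4CCC3CC4)nn2)cc1`, gives 449 nM.
Compound 2, `FCCOc1cccc(-c2cn([C@@H]3CN4CCC3CC4)nn2)c1`, gives 1260 nM.
Compound 3, `FCCOc1cccc(-c2cn(C3CN4CCC3CC4)nn2)c1`, gives 1960 nM.

These three compounds were measured in an assay on HEK293 cells for displacement of a labelled ligand from Neuronal acetylcholine receptor; alpha4/beta2 (Homo sapiens), read by scintillation counting, with a stated time of 120 min; on this read-out lower numbers stand for stronger inhibition and higher numbers for weaker inhibition. Among them compound 3 gives the highest number; compound 2 sits nearest to it, with a 1.6-fold higher number from compound 2 to compound 3 (0.19 log units; within the scatter), and compound 1 stands furthest from it. Compound 4, `Fc1ccc(COc2cccc(-c3cn(C4CN5CCC4CC5)nn3)c2)cc1`, is the one not yet measured. It differs from compound 3 as follows: 4-fluorophenyl in place of fluoromethyl on a saturated chain carbon bound to an oxygen on an aromatic ring. The only measured step among these compounds is the one from compound 2 to compound 3, which rests on the fact that one of compounds 2 and 3 is drawn with a defined configuration and the other without, at the place where they differ and touches no substituent; no measured step therefore bears on the change made in compound 4. Compound 1 and compound 3 differ in more than one place, so their values can only be set side by side. Without a relevant precedent, the step from compound 3 to compound 4 is expected to be modest, a 1.3-fold lower number from compound 3 to compound 4 (0.12 log units; within the scatter), and could fall in either direction or within the scatter. Compound 4 is therefore estimated at 1500 nM, within 500 nM to 5000 nM.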

Compound 4, inhibition constant: 1010 nM
Beside the measured number, compound 4's estimate is 1.5-fold (0.17 log units) above it; the range from low to high includes it.
By their numbers in this assay, from the lowest: compound 1; then compounds 4, 2 and 3 (each within the scatter of the next).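

In this assay, putting 4-fluorophenyl in place of fluoromethyl, on a saturated chain carbon bound to an oxygen on an aromatic ring, gives a 1.9-fold lower number from compound 3 to compound 4 (0.29 log units; within the scatter). Among the compounds shown here, this is the first measured change at this position, and it shows that a group of 7 heavy atoms with a six-membered aromatic ring can replace one of 2 heavy atoms with no ring while the read-out stays within the scatter. Nothing in the data shown accounts for the size of this step.

Still open, from the compounds shown here alone, is whether a different group at this position, such as an amine, a carboxylic acid or a longer chain, would move the number beyond the scatter. Also open, going by these compounds, is whether a defined configuration at the saturated ring carbon would matter in compound 4, which is drawn without one.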